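The source may report more compounds than this note shows. Statements on the series, on what has been measured and on what is new or still open speak of the compounds shown alone.

Measured compounds:
Compound 1, `CC(=O)Oc1ccccc1C1CC(C)=NN1C(=O)CN1CCC(C(C)=O)CC1`, in a functional assay on PC-3 cells (Homo sapiens) for cytotoxicity, read by MTT assay, with a stated time of 48 h; on this read-out lower numbers stand for stronger inhibition and higher numbers for weaker inhibition: 6800 nM
Compound 2, `O=C(c1ccccc1)N1N=C(c2cc3ccccc3oc2=O)CC1c1ccccc1`, in this assay: 5870 nM

For the measured compounds named here, only these two compounds carry numbers in this assay, and they are built on different cores, so no single-point step links them. Compound 2 gives the lower of the two numbers, yet compound 1 sits so close to it that the gap lies within the usual scatter of repeated measurements; no order between them can be claimed.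

Compound 3, `CN1CCN(CC(=O)N2N=C(c3cc4ccccc4oc3=O)CC2c2ccccc2)CC1`, has not yet been measured. It keeps the core of compound 2 and differs from it in a single place: (4-methylpiperazin-1-yl)methyl in place of phenyl on a carbonyl carbon. The change sits on a carbonyl carbon whose other neighbours are an amide-type nitrogen in a ring; everything else in the molecule is unchanged.

Going by the values given here, with no measured step of this kind to draw on, the expectation for compound 3 rests only on compound 2 and its value 5870 nM. The step from compound 2 to compound 3 in this assay is expected to stay within the scatter, a 1.0-fold higher number from compound 2 to compound 3 (0.01 log units; within the scatter), in no firm direction. Compound 3 is therefore estimated at 6000 nM, with a range from 2500 nM to 15000 nM.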

Compound 3, half-maximal inhibitory concentration: 25800 nM
The estimate for compound 3 lay 4.3-fold (0.63 log units) below the measured number; the measured number lies above the stated range.
By their numbers in this assay, from the lowest: compounds 2 and 1 (each within the scatter of the next); then compound 3.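

In this assay the carbonyl carbon whose other neighbour is the amide-type nitrogen in a ring turns out to be sensitive to what it carries: (4-methylpiperazin-1-yl)methyl in place of phenyl gives a 4.4-fold higher number from compound 2 to compound 3 (0.64 log units; beyond the scatter) and moves the number towards weaker inhibition. For the compounds shown here, the earlier pair sat on different cores and could say nothing about any single position, so this is the first reading of one place, with everything else in the molecule unchanged. The compounds shown offer no measurement that would account for this step.

As far as these compounds go, a single pair cannot separate the loss of the phenyl from the arrival of the (4-methylpiperazin-1-yl)methyl group, so it remains open whether a morpholin-4-ylmethyl group, a dimethylaminomethyl group or a 4-methoxyphenyl group on the same carbonyl carbon would stay close to compound 2 or shift as compound 3 does. From the compounds shown here alone, it is equally open whether this same exchange would produce a step of similar size and direction on any other core, as one step on one core sets no pattern.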